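Working notes on the imine substituent: compound 2 to compound 4

A few compounds are considered here, and "the series" means these few. Any claim that something is new, unique, unknown or untested is made for them only; others in the source may bear on it.

Measured so far in a functional assay on the whole organism (blood, strain Wistar-Okamoto) with Rattus norvegicus as the target, with a stated time of 5 days; on this read-out higher numbers stand for an effect only at larger amounts of compound and lower numbers for an effect already at smaller amounts:
compound 1 `CCC(C)/N=C(\NC#N)Nc1cccnc1` gives 20 mg/kg
compound 2 `N#CN/C(=N\C1CCCCC1)Nc1cccnc1` gives 20 mg/kg
compound 3 `CC(C)(C)C(C)(C)/N=C(\NC#N)Nc1cccnc1` gives 50 mg/kg

Compound 2 stands level with compound 1 at the digits printed, the two together the lowest numbers of the three; compound 3 sits higher, beyond the scatter. The step of no change at the digits printed from compound 1 to compound 2 (within the scatter) shows that exchanging one saturated group for another on the double-bonded nitrogen left the read-out unchanged.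

Compound 4 `N#CN/C(=N\c1ccccc1)Nc1cccnc1` is not yet measured. It differs from compound 2 in one place: phenyl in place of cyclohexyl on a double-bonded nitrogen. Within the data shown here, no measured step swaps a saturated ring for an aromatic one, so the only bearing precedent is the flat step from compound 1 to compound 2. The expected step of no change at the digits printed from compound 2 to compound 4 (within the scatter) is therefore none beyond the scatter, with the wider range reflecting the missing precedent. For compound 4 in this assay the estimate is 20 mg/kg, between 10 mg/kg and 50 mg/kg.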

Compound 4, minimum effective dose: 5 mg/kg
Compound 4: the middle estimate sits 4.0-fold (0.60 log units) above what was measured, outside the stated range (below it).
By their numbers in this assay, from the lowest: compound 4; then compounds 1 and 2 (each within the scatter of the next); then compound 3.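

In this assay the double-bonded nitrogen proves sensitive to the kind of ring it carries: with the heavy-atom count unchanged, phenyl in place of cyclohexyl gives a 4.0-fold lower number from compound 2 to compound 4 (0.60 log units; beyond the scatter) while the saturated exchange gave no such shift. Phenyl in place of sec-butyl gives a step of the same printed size (a 4.0-fold lower number from compound 1 to compound 4 (0.60 log units; beyond the scatter)), so among these compounds only the aromatic group lowers the number beyond the scatter. No evidence is available to explain this difference. Still open, from the compounds shown here alone, is whether a chlorophenyl, a methoxyphenyl or a benzyl group on this nitrogen would keep the lower number.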